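The compounds below may be only part of what the source reports. "The series", "measured", "known", "first", "only" and "open" are said of these compounds alone.

Measured in an ADME assay on TZM cells (Homo sapiens) for cytotoxicity, read by XTT assay, with a stated time of 4 days; on this read-out higher numbers stand for lower toxicity in this test and lower numbers for higher toxicity in this test:
Compound 1 `Cc1cc(Br)cc(C)c1Oc1ccc([N+](=O)[O-])c(Nc2ccc(C#N)cc2)n1`: > 45600 nM, a limit of the assay.
Compound 2 `Cc1cc(Br)cc(C)c1Oc1ccc(N)c(Nc2ccc(C#N)cc2)n1`: 15500 nM.

Within the data shown here, compound 2 holds the only exact number, 15500 nM. Compound 3 `CC(=O)CCc1cc(C)c(Oc2ccc(N)c(Nc3ccc(C#N)cc3)n2)c(C)c1` has 2-acetylethyl in place of bromo on an aromatic carbon. Among the measured compounds shown here, the only measured step, an at least 2.9-fold lower number from compound 1 to compound 2 (0.46 log units; beyond the scatter), is amino in place of nitro, a different change, so it says nothing direct about this swap. With no measured guide, the expectation stays with compound 2 at 15500 nM, and no change beyond the scatter is expected. The expected step is a 1.0-fold lower number from compound 2 to compound 3 (0.01 log units; within the scatter). Compound 3 is estimated at 15000 nM, with an expected range from 5000 nM to 45000 nM.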

Compound 3, half-maximal cytotoxic concentration: 9250 nM
For compound 3 the middle estimate is 1.6-fold (0.21 log units) above the measured one; the measured number falls inside the stated range.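

In this assay, 2-acetylethyl in place of bromo gives a 1.7-fold lower number from compound 2 to compound 3 (0.22 log units; within the scatter) at this aromatic carbon, meta to two methyl groups. At this position, then, a group of 5 heavy atoms with a hydrogen-bond acceptor reads the same as a single bromine, which the earlier step, made at another place, could not show. Nothing at hand gives a cause for this step. On these data alone, whether an amine, a carboxylic acid or a longer chain here would read the same stays open. Also open, as far as these compounds go, is whether this swap would read alike with nitro in place of amino on the shared core.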